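An indole in place of an acetylphenyl: cytotoxicity outlook

The source may report more compounds than this note shows. Statements on the series, on what has been measured and on what is new or still open speak of the compounds shown alone.

Compound 1 `CC(=O)c1cccc(-c2ccc(C(=O)N(Cc3cccc(OCCCCCC(=O)O)c3)C(C)C)cc2)c1` is the starting point. In an ADME assay on HepG2 cells (Homo sapiens) for cytotoxicity, read by CellTiter-Glo and resazurin assay, with a stated time of 72 h (on this read-out lower numbers stand for an effect already at smaller amounts and higher numbers for an effect only at larger amounts of compound), compound 1 gives only a limit, > 26000 nM. Compound 2 `CC(C)N(Cc1cccc(OCCCCCC(=O)O)c1)C(=O)c1ccc(-c2cccc(Oc3ccccc3)c2)cc1` carries phenoxy in place of acetyl on an aromatic carbon. In this assay compound 2 likewise gives only a limit, > 18700 nM. The step that the two limits leave unreadable from compound 1 to compound 2 therefore cannot be sized, since both values sit at limits of the assay (the limit of > 18700 nM in this assay, at which 1 of the 2 values shown sits, (the limit of > 26000 nM in this assay, at which 1 of the 2 values shown sits)). Compound 3 `CC(C)N(Cc1cccc(OCCCCCC(=O)O)c1)C(=O)c1ccc(-c2ccc3[nH]ccc3c2)cc1` differs from compound 1 by 1H-indol-5-yl in place of 3-acetylphenyl on an aromatic carbon. Among the compounds with values here, no measured step yields a readable number, so the change from compound 1 to compound 3 has no directly comparable precedent; what the two measured compounds show is that neither reaches an effect within the tested range. Compound 3 is therefore expected to behave alike, with an estimated value of 30000 nM (range 12000 nM to 100000 nM), most likely once more reported only as a limit. The expected step that the limit leaves unreadable from compound 1 to compound 3 is estimated to lie within the scatter.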

Compound 3, half-maximal effective concentration: > 26000 nM
Compound 3 gave a limit, no number; the forecaster's own chance of this, stated with the estimate: 80%; the middle value lies beyond the limit too.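

In this assay compound 3 gives > 26000 nM, a limit and not a number. Compound 1 gives a limit too, and no step can be read from compound 1 to compound 3. The compounds shown leave open at what concentration, if any, compound 1, compound 2 or compound 3 would reach a half-maximal effect.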